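Removing the Acyl Group from Compound 3

The compounds below may be only part of what the source reports. "The series", "measured", "known", "first", "only" and "open" are said of these compounds alone.

The measured compounds, with their results in a functional assay on HeLa cells (Homo sapiens) for cytotoxicity, read by cell counting, with a stated time of 4 days; a lower number here means a stronger inhibitor, a higher number a weaker inhibitor:

Compound 1, `CC(C)(C)c1ccc(CN2C(=O)S/C(=C\c3cccc(N)c3)C2=O)cc1`, gives 145000 nM.
Compound 2, `Nc1ccc(/C=C2\SC(=O)N(Cc3ccccc3)C2=O)cc1`, gives 46000 nM.
Compound 3, `C=C(Br)C(=O)Nc1cccc(/C=C2\SC(=O)N(Cc3ccccc3)C2=O)c1`, gives 1400 nM.

Compound 3 stands lowest of the three numbers, and both of the others lie well above it, beyond the usual scatter: compound 2 with 46000 nM is the nearer, compound 1 with 145000 nM the further. The unmeasured compound 4, `Nc1cccc(/C=C2\SC(=O)N(Cc3ccccc3)C2=O)c1`, is compound 3 with one change: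

hydrogen in place of (1-bromoethenyl)carbonyl on a nitrogen on an aromatic ring

Going by the values given here, no step between two measured compounds shows this change directly. What the data do show is this: compound 4 carries an amino group on its ring and the same benzyl group as compound 2, and compound 2 gives 46000 nM. Compound 4 also carries an amino group on its ring as compound 1 does, though with a different benzyl group, and compound 1 gives 145000 nM. Both of these amino compounds sit far above compound 3. On that basis the step is expected to be large and toward a higher number, with a 50-fold higher number from compound 3 to compound 4 (1.70 log units; beyond the scatter) as the expected change. Compound 4 is therefore estimated at 70000 nM, with a likely range from 20000 nM to 250000 nM.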

Compound 4, half-maximal inhibitory concentration: > 250000 nM
Compound 4: a limit, no number; the forecaster's own chance of this, stated with the estimate: 10%; middle value at least 3.5-fold (0.55 log units) away from the limit.
By their numbers in this assay, from the lowest: compound 3; then compound 2; then compound 1. At a limit, above all of these: compound 4.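

In this assay compound 4 stands at a limit of the assay, not at a number: the limit of > 250000 nM in this assay, at which 1 of the 4 values shown sits.

Taking the (1-bromoethenyl)carbonyl group off the nitrogen on the aromatic ring gives an at least 170-fold higher number from compound 3 to compound 4 (2.25 log units; beyond the scatter), the first one-place view of this change, and it shows that the low number of compound 3 is lost once only the plain amino group remains at this position. The two amino compounds can now be set against compound 4 as well: 3-aminophenyl in place of 4-aminophenyl gives an at least 5.4-fold higher number from compound 2 to compound 4 (0.73 log units; beyond the scatter), while hydrogen in place of tert-butyl on an aromatic carbon gives an at least 1.7-fold higher number from compound 1 to compound 4 (0.23 log units; that floor lies within the scatter), and since that floor lies within the scatter, this last step sets no order between the two compounds.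

The compounds shown leave open which part of the (1-bromoethenyl)carbonyl group carries the step, the bromine, the double bond or the carbonyl, and a plain acetyl group or a bromine-free propenoyl group on the same nitrogen would begin to separate these. Also open, from the compounds shown here alone, is whether the same group, placed on the amino nitrogen of compound 2 or of compound 1, would give a step of similar size.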